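Swapping the six-atom group for dimethylcarbamoyl

The compounds below may be only part of what the source reports. "The series", "measured", "known", "first", "only" and "open" are said of these compounds alone.

Compound 1 `CC/N=C(/N)Nc1nc(-c2ccc(OC)cc2)c(-c2ccc(OC)cc2)s1` stands at a limit in a functional assay with Oryctolagus cuniculus as the target; a lower number here means a stronger inhibitor, a higher number a weaker inhibitor: compound 1 gives > 100 nM, which is a limit of the assay and not a number (the limit of > 100 nM in this assay, at which 1 of the 2 values shown sits). Compound 2 `COc1ccc(-c2nc(/N=C(\N)N(C)C)sc2-c2ccc(OC)cc2)cc1` carries a different six-atom group on the same aromatic carbon, and in this assay compound 2 gives 37 nM. That change produced an at least 2.7-fold lower number from compound 1 to compound 2 (0.43 log units; beyond the scatter). Compound 3 `COc1ccc(-c2nc(C(=O)N(C)C)sc2-c2ccc(OC)cc2)cc1` differs from compound 1 by a group of 5 heavy atoms (3 carbon, 1 nitrogen, 1 oxygen; no ring) in place of a group of 6 heavy atoms (3 carbon, 3 nitrogen; no ring), on an aromatic carbon. Going by the values given here, only the step from compound 1 to compound 2 bears on this change, and it concerns a related but not identical replacement at the same place, so it offers limited guidance. The starting point is itself a limit, and the size of the new step can therefore be read only loosely. The expected step is a step that the limit leaves unreadable from compound 1 to compound 3, with wide uncertainty. Compound 3 is estimated at 150 nM, in the range 30 nM to 1000 nM.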

Compound 3, half-maximal inhibitory concentration: < 100 nM
Compound 3 ended at the assay's limit; the forecaster's own chance of this, stated with the estimate: 45%; at least 1.5-fold (0.17 log units) between middle value and limit.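

In this assay compound 3 gives < 100 nM, which is a limit of the assay and not a number. Even so, the change has a readable direction: dimethylcarbamoyl, with 0 hydrogen-bond donors against 2 in the group it replaces, gives a number no higher from compound 1 to compound 3 (the limit leaves the size open), so a group with 3 nitrogen atoms is not required on this aromatic carbon for a value on the stronger side of that limit. The sizes of this step and of the step from compound 2 to compound 3 cannot be read, because compound 3 sits at a limit: the limit of < 100 nM in this assay, at which 1 of the 3 values shown sits.

The compounds shown do not settle whether compound 3 is stronger or weaker than compound 2. They also leave open how a carboxylic acid, a primary amide or a diethylcarbamoyl group would behave on this carbon.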